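The source may report more compounds than this note shows. Statements on the series, on what has been measured and on what is new or still open speak of the compounds shown alone.

Measured so far in an assay on blood for inhibition of Polyunsaturated fatty acid 5-lipoxygenase (Homo sapiens); a higher number here means a weaker inhibitor, a lower number a stronger inhibitor:
compound 1, `CC(=O)C1(c2cc(F)cc(OCc3ccc(-n4ccnc4C)cc3)c2)CCOCC1`: 130 nM
compound 2, `Cc1nccn1-c1ccc(COc2cc(F)cc(C3(C(N)=O)CCOCC3)c2)cc1`: 340 nM
compound 3, `Cc1nccn1-c1ccc(COc2cc(F)cc(C3(C(=O)N(C)C)CCOCC3)c2)cc1`: 810 nM

Compound 3 gives the highest number of the three; the nearest is compound 2, the furthest compound 1. Compound 4, `Cc1nccn1-c1ccc(COc2cc(F)cc(C3([S+](C)[O-])CCOCC3)c2)cc1`, differs from compound 3 at one place: a group of 3 heavy atoms (1 carbon, 1 oxygen, 1 sulfur; no ring) in place of a group of 5 heavy atoms (3 carbon, 1 nitrogen, 1 oxygen; no ring), on a saturated ring carbon. The measured steps all exchange what sits on the carbonyl carbon: a 2.6-fold higher number from compound 1 to compound 2 (0.42 log units; beyond the scatter), a 6.2-fold higher number from compound 1 to compound 3 (0.79 log units; beyond the scatter) and a 2.4-fold higher number from compound 2 to compound 3 (0.38 log units; beyond the scatter). Each is modest, and the methyl of compound 1 goes with the lowest number. Compound 4 keeps no carbonyl at this position, so these steps bear on it only loosely; a number between those of compound 1 and compound 3 is expected, with wide uncertainty. Compound 4 is expected at about 300 nM, within 80 nM to 1200 nM. That estimate means a 2.7-fold lower number from compound 3 to compound 4 (0.43 log units; beyond the scatter).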

Compound 4, half-maximal inhibitory concentration: > 1000 nM
Compound 4: a limit, no number (the forecaster's own chance of this, stated with the estimate: 5%); at least 3.3-fold (0.52 log units) between middle value and limit.
By their numbers in this assay, from the lowest: compound 1; then compound 2; then compound 3. At a limit, above all of these: compound 4.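

In this assay compound 4 gives > 1000 nM, a limit of the assay and not a number. On this saturated ring carbon, a group without a carbonyl goes with a clearly weaker result than the two smaller carbonyl groups, with an at least 7.6-fold higher number from compound 1 to compound 4 (0.88 log units; beyond the scatter) and an at least 2.9-fold higher number from compound 2 to compound 4 (0.46 log units; beyond the scatter). The remaining step, an at least 1.2-fold higher number from compound 3 to compound 4 (0.09 log units; that floor lies within the scatter), sets no order between those two compounds. As far as these compounds go, the true number for compound 4 stays open. So does whether a hydroxyl or a nitrile on this ring carbon would match the methyl ketone of compound 1.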